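Pyrimidin-2-yl in place of 4-methylpyridin-2-yl

This account rests on a few compounds, and the source may have more. Where it says the series, first, only, none or still open, it means among the compounds named here.

In a physicochemical assay for lipophilicity, read by HPLC, at pH 7.4 (on this read-out lower numbers stand for lower lipophilicity and higher numbers for higher lipophilicity), compound 1 `Cc1ccc([C@@H](C)Oc2cc3oc(=O)n(CCC(=O)O)c3cc2Cl)nc1` gives 2.02 and compound 2 `Cc1ccnc([C@@H](C)Oc2cc3oc(=O)n(CCC(=O)O)c3cc2Cl)c1` gives 2.15, so compound 2 stands level with compound 1 within the scatter. Compound 3 `C[C@@H](Oc1cc2oc(=O)n(CCC(=O)O)c2cc1Cl)c1ncccn1` is still unmeasured. Its difference from compound 2 is pyrimidin-2-yl in place of 4-methylpyridin-2-yl on a saturated chain carbon bound to an oxygen on an aromatic ring and a saturated chain carbon. For the measured compounds named here, the only measured step that bears on this is a number 0.13 log units higher from compound 1 to compound 2 (within the scatter), with 4-methylpyridin-2-yl in place of 5-methylpyridin-2-yl. Going by the values given here, no measured step removes the methyl or alters the ring's hetero atoms, so that step sets no size for this change. Judged from the structural change alone, a fall beyond the scatter is expected in this assay. The expected step is a number 0.75 log units lower from compound 2 to compound 3 (beyond the scatter). For compound 3 the estimate is 1.4, with an expected range of 1.05 to 1.75.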

Compound 3, distribution coefficient: 0.83
Compound 3: middle estimate off by 0.57 log units, on the high side, and the stated range ends above it.
By their numbers in this assay, from the lowest: compound 3; then compounds 1 and 2 (each within the scatter of the next).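

In this assay this place on the saturated chain carbon responds strongly to the identity of the ring: pyrimidin-2-yl gives a number 1.32 log units lower from compound 2 to compound 3 (beyond the scatter) and a number 1.19 log units lower from compound 1 to compound 3 (beyond the scatter), both large, whereas exchanging the two methylpyridines gave only a number 0.13 log units higher from compound 1 to compound 2 (within the scatter). The change carries two differences at once, the loss of the methyl and the entry of a second ring nitrogen, and the fall appears from either methylpyridine. Nothing measured here gives a cause for the size of the fall.

On these data alone, how the fall divides between the lost methyl and the added ring nitrogen remains open. Unsubstituted pyridin-2-yl and a methylpyrimidin-2-yl at this place would separate the two contributions, and a methoxy group on the pyrimidin-2-yl ring would show whether the number can be raised again.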